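The source may report more compounds than this note shows. Statements on the series, on what has been measured and on what is new or still open speak of the compounds shown alone.

In an assay for inhibition of acid-sensing ion channel 3 (Homo sapiens), read by patch clamp, tested at 20 uM (a higher number here means more inhibition at the concentration tested (going by the name of the read-out), a lower number less inhibition), compound 1 `NC(N)=NC(=O)c1nc(Cl)c(NC2CC2)nc1N` gives 78%, compound 2 `NC(N)=NC(=O)c1nc(Cl)c(NC2CCCCC2)nc1N` gives 92%, and compound 3 `NC(N)=NC(=O)c1nc(Cl)c(Nc2ccccn2)nc1N` gives 25%. Compound 3 stands lowest of the three: the steps of a number 53 percentage points lower from compound 1 to compound 3 (beyond the scatter) and a number 67 percentage points lower from compound 2 to compound 3 (beyond the scatter) are both large, while a number 14 percentage points higher from compound 1 to compound 2 (beyond the scatter) is modest. Compound 4 `NC(N)=NC(=O)c1nc(Cl)c(O)nc1N` differs from compound 3 by hydroxy in place of (pyridin-2-yl)amino on an aromatic carbon. Within the data shown here, all three measured steps exchange one group on that nitrogen for another; none removes the (pyridin-2-yl)amino group altogether, so no measured step bears directly on this change, and the expectation rests on compound 3 alone. The step expected in this assay is a number 5 percentage points lower from compound 3 to compound 4 (within the scatter), small against a wide uncertainty. For compound 4 the estimate in this assay is 20%, ranging from 0% to 55%.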

Compound 4, a percentage reported as inhibition, at one concentration (the size of the read-out at that concentration, not a potency): 9%
Compound 4: middle estimate off by 11 percentage points, on the high side, within the range that was stated.
By their numbers in this assay, from the lowest: compound 4; then compound 3; then compound 1; then compound 2.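

In this assay, hydroxy on this aromatic carbon gives less inhibition than each of the three amino groups shown: a number 16 percentage points lower from compound 3 to compound 4 (beyond the scatter), a number 69 percentage points lower from compound 1 to compound 4 (beyond the scatter) and a number 83 percentage points lower from compound 2 to compound 4 (beyond the scatter). The earlier steps shown here only exchanged groups on the nitrogen, whereas this change removes the nitrogen with its substituent, and the (pyridin-2-yl)amino group still holds a modest margin over hydroxy. No evidence given here accounts for these drops. As far as these compounds go, whether the loss comes from removing the nitrogen or from hydroxy itself stays open. An unsubstituted amino group or a methoxy group on this carbon would separate the two.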